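Adding chloro to compound 2

This account rests on a few compounds, and the source may have more. Where it says the series, first, only, none or still open, it means among the compounds named here.

Compound 1 `CCCCCC(CCO)n1cnc2c(Cl)nc(Cl)nc21` gives 6010 nM in a functional assay on SW480 cells (Homo sapiens) for antiproliferative activity, read by MTT assay, with a stated time of 48 h; a lower number here means a stronger inhibitor, a higher number a weaker inhibitor. Compound 2 `CCCCCC(CCO)n1cnc2c(N)ncnc21` gives > 50000 nM in this assay. That value is a limit of the assay and not a number. Compound 2 therefore has no exact place on the scale, and the two values show only a measured number for compound 1 and a limit for compound 2.

Compound 3 `CCCCCC(CCO)n1cnc2c(N)nc(Cl)nc21` keeps the amino group of compound 2 and takes chloro in place of hydrogen on an aromatic carbon, between two ring nitrogen atoms: chloro in place of hydrogen on an aromatic carbon. Within the data shown here, no measured step isolates this change, so its size can only be judged indirectly. A gain in potency beyond the usual scatter is expected in this assay because compound 1, which also carries chloro on the core, gives 6010 nM. The gain is expected to be moderate, and compound 3 may not reach the level of compound 1. The estimated change is an at least 2.5-fold lower number from compound 2 to compound 3 (0.39 log units; beyond the scatter). For compound 3 the expected value is 20000 nM, with an estimated range from 7000 nM to 50000 nM.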

Compound 3, half-maximal inhibitory concentration: > 50000 nM
Compound 3: no number, only a limit; the forecaster's own chance of this, stated with the estimate: 30%; at least 2.5-fold (0.39 log units) between middle value and limit.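

In this assay compound 3 gives > 50000 nM, which is a limit of the assay and not a number, so chloro on this aromatic carbon, between two ring nitrogen atoms, does not by itself yield a measurable potency on the amino-bearing core. The size of the change from hydrogen to chloro cannot be read, because the values for the two compounds that differ by this change both stop at the same limit: the limit of > 50000 nM in this assay, at which 2 of the 3 values shown sit. Among these compounds, the one readable step concerns the other place on the core: with chloro kept between the two ring nitrogen atoms, amino in place of chloro on an aromatic carbon gives an at least 8.3-fold higher number from compound 1 to compound 3 (0.92 log units; beyond the scatter), which ties the measured number of compound 1 to the chloro that compound 3 lacks at that carbon.

Whether the chloro between the two ring nitrogen atoms contributes anything to compound 1 remains open, since no compound shown carries hydrogen there alongside chloro at the other carbon. As far as these compounds go, it is also open whether a group such as methoxy or a methylamine in place of the amino group would bring the core back to a measured number.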